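Sulfonyl substituent change from compound 3 to compound 4

A few compounds are considered here, and "the series" means these few. Any claim that something is new, unique, unknown or untested is made for them only; others in the source may bear on it.

The series keeps a shared core and varies the group on a sulfonyl sulfur. In a physicochemical assay for solubility, in phosphate buffer, with a stated time of 24 h, at pH 7.4, tested at 100 uM (on this read-out lower numbers stand for lower solubility and higher numbers for higher solubility), compound 1 `O=C(NCc1ccc(S(=O)(=O)c2ccccc2)cc1)N1Cc2ccncc2C1` gives 115000 nM, compound 2 `O=C(NCc1ccc(S(=O)(=O)c2cncc(C(F)(F)F)c2)cc1)N1Cc2ccncc2C1` gives 83000 nM and compound 3 `O=C(NCc1ccc(S(=O)(=O)C2CCCOC2)cc1)N1Cc2ccncc2C1` gives 208000 nM. The position of the third value is mixed: a 2.5-fold higher number from compound 2 to compound 3 (0.40 log units; beyond the scatter) is modest but beyond the scatter, whereas a 1.8-fold higher number from compound 1 to compound 3 (0.26 log units; within the scatter) stays within it. The remaining comparison, a 1.4-fold lower number from compound 1 to compound 2 (0.14 log units; within the scatter), is also within the scatter.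

Compound 4 `CCC(=O)N1CCC(S(=O)(=O)c2ccc(CNC(=O)N3Cc4ccncc4C3)cc2)CC1` has not yet been measured. It carries 1-propanoylpiperidin-4-yl in place of oxan-3-yl on a sulfonyl sulfur. For the measured compounds named here, both groups hold one six-membered non-aromatic ring with 1 hetero atom, but no measured step tests this exact replacement. All three measured steps change the group at this same place, and the largest is a 2.5-fold higher number from compound 2 to compound 3 (0.40 log units; beyond the scatter). On that evidence, no large change is expected, and the direction is uncertain. The expected change is a 1.3-fold lower number from compound 3 to compound 4 (0.11 log units; within the scatter), which would not go beyond the scatter. In this assay compound 4 is estimated at 160000 nM, with an expected range of 80000 nM to 280000 nM.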

Compound 4, solubility: 216000 nM
Compound 4: the middle estimate sits 1.4-fold (0.13 log units) below what was measured; low and high end bracket the measured number.
By their numbers in this assay, from the lowest: compounds 2, 1, 3 and 4 (each within the scatter of the next, the first and the last beyond it).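

For the compounds shown here, replacing oxan-3-yl (6 heavy atoms) with 1-propanoylpiperidin-4-yl (10 heavy atoms) on a sulfonyl sulfur gives no step that can be told from the scatter in this assay (a 1.0-fold higher number from compound 3 to compound 4 (0.02 log units; within the scatter)), so this position accepts the larger non-aromatic group, with its added double bond outside aromatic rings, without a resolved shift. Against the aromatic groups, compound 4 repeats the picture seen for compound 3: the step from the 5-(trifluoromethyl)pyridin-3-yl group is modest but beyond the scatter (a 2.6-fold higher number from compound 2 to compound 4 (0.42 log units; beyond the scatter)), while the step from phenyl stays within it (a 1.9-fold higher number from compound 1 to compound 4 (0.27 log units; within the scatter)), so compound 1 goes against any clean split between aromatic and non-aromatic groups. Nothing in hand bears on the origin of these steps.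

Still open, as far as these compounds go, is whether a free piperidine amine, a carboxylic acid or a longer acyl chain in place of the propanoyl group would take the number beyond the scatter from compound 4. Also open, from the compounds shown here alone, is whether any non-aromatic group at this position separates from phenyl, since neither compound 3 nor compound 4 does.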